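The source may hold more compounds than are shown below. What is called first, only, known or untested is meant among the compounds shown, and "the series" means these compounds.

In a functional assay on MDA-MB-231 cells (Homo sapiens) for antiproliferative activity, with a stated time of 4 days (on this read-out higher numbers stand for weaker inhibition and lower numbers for stronger inhibition), compound 1 `CCCCc1ccc2[nH]c(-c3ccc(OC)cc3)c(C=O)c2c1` gives 6.7 nM, while compound 2 `CCCCc1ccc2[nH]c(-c3ccc(OC)cc3)c(/C=N/NC(=O)c3ccc(OC)cc3)c2c1` gives 61 nM. Compound 2 therefore has the higher of the two numbers and is the weaker inhibitor, by a gap beyond the usual scatter. Compound 3 `CCCCc1ccc2[nH]c(-c3ccc(OC)cc3)c(/C=N/NC(=O)c3ccncc3)c2c1` has not yet been measured. It differs from compound 2 in one place: pyridin-4-yl in place of 4-methoxyphenyl on a carbonyl carbon, with pyridin-4-yl in place of 4-methoxyphenyl on a carbonyl carbon. Within the data shown here, no measured pair shows this exchange, so the expected step in this assay, a 1.3-fold higher number from compound 2 to compound 3 (0.12 log units; within the scatter), stays within the scatter and has no firm direction. For compound 3 the estimated value is 80 nM, with an expected range of 20 nM to 320 nM.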

Compound 3, half-maximal inhibitory concentration: 29 nM
Estimate against measurement, compound 3: 2.8-fold (0.44 log units) above; the range from low to high includes it.
By their numbers in this assay, from the lowest: compound 1; then compound 3; then compound 2.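

In this assay, putting pyridin-4-yl in place of 4-methoxyphenyl on a carbonyl carbon gives a 2.1-fold lower number from compound 2 to compound 3 (0.32 log units; beyond the scatter). Among these compounds, this is the first sign that the group on this carbonyl carbon can change the number, although the step is modest. Nothing measured here explains the change. The compounds shown leave open whether a plain phenyl group, with no methoxy group and no ring nitrogen, would give a number closer to that of compound 2 or compound 3. From the compounds shown here alone, how a piperidine ring would fare on this carbonyl carbon also remains open.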